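The source may hold more compounds than are shown below. What is called first, only, known or untested is meant among the compounds shown, and "the series" means these compounds.

Measured so far:
compound 1 `CCC/C=C/C=C/c1cc(C#N)ccc1COC(c1ccc(C#N)cc1)c1cncn1C` — 16.7 nM
compound 2 `Cn1cncc1C(OCc1ccc(C#N)cc1/C=C/c1ccccn1)c1ccc(C#N)cc1` — 23.1 nM

In a functional assay on NIH3T3 cells (Mus musculus) (on this read-out lower numbers stand for an effect already at smaller amounts and higher numbers for an effect only at larger amounts of compound), compound 1 gives 16.7 nM and compound 2 gives 23.1 nM. Among the measured compounds shown here, compound 2 stands alongside compound 1, the two values within the scatter of each other; the one known step, a 1.4-fold higher number from compound 1 to compound 2 (0.14 log units; within the scatter), changes only the group on the double-bonded chain. Compound 3 `Cn1cncc1C(OCc1ccc(C#N)cc1C#CCCc1ccccc1)c1ccc(C#N)cc1` is still unmeasured. Change: 4-phenylbut-1-yn-1-yl in place of 2-(pyridin-2-yl)ethenyl on an aromatic carbon. For the measured compounds named here, no measured step exchanges the whole double-bonded chain for a triple-bonded one, and the only step at this position, a 1.4-fold higher number from compound 1 to compound 2 (0.14 log units; within the scatter), lies within the scatter, so no step beyond the scatter is expected in this assay. Compound 3 is expected at 25 nM (range 8 nM to 80 nM), a step of a 1.1-fold higher number from compound 2 to compound 3 (0.03 log units; within the scatter).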

Compound 3, half-maximal effective concentration: 130 nM
Estimate against measurement, compound 3: 5.2-fold (0.72 log units) below, and the stated range ends below it.
By their numbers in this assay, from the lowest: compounds 1 and 2 (each within the scatter of the next); then compound 3.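

In this assay this aromatic carbon is not indifferent to its substituent: with 4-phenylbut-1-yn-1-yl in place of either double-bonded chain, a 5.6-fold higher number from compound 2 to compound 3 (0.75 log units; beyond the scatter) and a 7.8-fold higher number from compound 1 to compound 3 (0.89 log units; beyond the scatter) both lie beyond the scatter. The earlier exchange between the two double-bonded chains gave no such separation. No data on hand account for this shift. The compounds shown do not separate the triple bond from the longer chain or from the terminal phenyl. Going by these compounds, how an amine or a carboxylic acid at the chain end would read also stays open.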